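The source may hold more compounds than are shown below. What is called first, only, known or untested is meant among the compounds shown, and "the series" means these compounds.

Compound 1 `Cc1cc(=O)n(-c2ccc(Br)cc2F)nc1C(=O)Nc1ccc(Oc2ncnc3ccsc23)c(F)c1` gives 1550 nM in a functional assay on MCF7 cells (Homo sapiens) for cytotoxicity, read by MTT assay, with a stated time of 72 h; a lower number here means a stronger inhibitor, a higher number a weaker inhibitor. For the measured compounds named here, compound 2 `Cc1cc(=O)n(-c2ccccc2OC(F)(F)F)nc1C(=O)Nc1ccc(Oc2ncnc3ccsc23)c(F)c1`, which carries 2-(trifluoromethoxy)phenyl in place of 4-bromo-2-fluorophenyl on an aromatic nitrogen, gives 11500 nM in this assay, and the step of a 7.4-fold higher number from compound 1 to compound 2 (0.87 log units; beyond the scatter) is the only measured step in the set. Compound 3 `Cc1cc(=O)n(-c2ccc(Br)cc2F)nc1C(=O)Nc1ccc(Oc2ncnc3sccc23)cc1` is built on a different core; the difference between the two cores is not broken down here. In this assay compound 3 gives 15200 nM, which is within the scatter of the number for compound 2 and stands well apart from compound 1. Compound 4 `Cc1cc(=O)n(-c2ccccc2OC(F)(F)F)nc1C(=O)Nc1ccc(Oc2ncnc3sccc23)cc1` is the still unmeasured partner of compound 3 and carries 2-(trifluoromethoxy)phenyl in place of 4-bromo-2-fluorophenyl on an aromatic nitrogen, the same change as that from compound 1 to compound 2. Going by the values given here, since the one measured instance of this change gave a 7.4-fold higher number from compound 1 to compound 2 (0.87 log units; beyond the scatter), a step of the same kind is expected, estimated as a 3.3-fold higher number from compound 3 to compound 4 (0.52 log units; beyond the scatter), though with wider uncertainty because compound 3 already gives 15200 nM. Compound 4 is therefore expected to give about 50000 nM in this assay, estimated between 15000 nM and 150000 nM.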

Compound 4, half-maximal inhibitory concentration: 11000 nM
Compound 4: the middle estimate sits 4.5-fold (0.66 log units) above what was measured; measured number below the stated range.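

On the core of compound 3, placing 2-(trifluoromethoxy)phenyl in place of 4-bromo-2-fluorophenyl on the aromatic nitrogen gives a 1.4-fold lower number from compound 3 to compound 4 (0.14 log units; within the scatter) in this assay, so the clear rise in the number seen on the core of compound 1 does not reappear here. The change therefore does not transfer between these two cores with a constant size: the same change on two cores in this assay, a 7.4-fold higher number (0.87 log units; beyond the scatter) from compound 1 to compound 2 and a 1.4-fold lower number (0.14 log units; within the scatter) from compound 3 to compound 4, 10-fold (1.01 log units) apart, beyond the scatter of two such steps. This rests on a single pair per core, and it shows neither why the two cores respond differently nor how the change would behave on a third core.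

The compounds shown leave open which structural difference between the core of compound 1 and the core of compound 3 governs the response to this change. Also open, from the compounds shown here alone, is how either core responds to other groups on the aromatic nitrogen, for example a phenyl ring carrying an amine or a carboxylic acid, or to a longer chain in place of the methyl group.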